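The compounds below may be only part of what the source reports. "The series", "measured", "known", "first", "only" and "open" are said of these compounds alone.

Measured so far:
Compound 1, `O=C(O)COCCCCC1=CCC[C@@H]1NS(=O)(=O)c1ccc(Cl)c(Cl)c1` — 1900 nM
Compound 2, `O=C(O)CC/C=C\CC1=CCC[C@@H]1NS(=O)(=O)c1ccc(Cl)c(Cl)c1` — 1900 nM
Compound 3, `O=C(O)CC/C=C\C[C@H]1[C@H](F)CC[C@@H]1NS(=O)(=O)c1ccc(Cl)cc1` — 210 nM

In a functional assay on a cell-free system (plasma) for inhibition of thromboxane A2 receptor (Homo sapiens), read by turbidimetry (a higher number here means a weaker inhibitor, a lower number a stronger inhibitor), compound 1 stands level with compound 2, the two together giving the highest numbers; compound 3 gives a markedly lower number. The step from compound 1 to compound 4, `O=C(O)COCCCCC1=CCC[C@@H]1NS(=O)(=O)c1ccccc1`, replaces (phenyl in place of 3,4-dichlorophenyl on a sulfonyl sulfur). Among the measured compounds shown here, the only single-place step with numbers, no change at the digits printed from compound 1 to compound 2 (within the scatter), touches the chain and not the sulfonyl group, so nothing measured bears directly on this change; compound 3 also carries a chlorophenyl, but it differs at several places. In this assay a modest rise is therefore expected, a 2.6-fold higher number from compound 1 to compound 4 (0.42 log units; beyond the scatter), with wide uncertainty. Compound 4 is estimated at 5000 nM, likely between 1500 nM and 20000 nM.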

Compound 4, half-maximal inhibitory concentration: 2000 nM
Compound 4: the middle estimate sits 2.5-fold (0.40 log units) above what was measured; the measured number falls inside the stated range.
By their numbers in this assay, from the lowest: compound 3; then compounds 1, 2 and 4 (each within the scatter of the next).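

In this assay, swapping 3,4-dichlorophenyl for phenyl on the sulfonyl sulfur gives a 1.1-fold higher number from compound 1 to compound 4 (0.02 log units; within the scatter) and so leaves the number unchanged within the scatter. On the core of compound 1, then, the two chlorine atoms are not needed for this level of inhibition. No measurement shown explains this result. Still open, as far as these compounds go, is whether a larger or differently built group on the sulfonyl sulfur, such as naphthyl or 4-methoxyphenyl, would move the number, and whether phenyl would serve equally well on the core of compound 3.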